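This account rests on a few compounds, and the source may have more. Where it says the series, first, only, none or still open, it means among the compounds named here.

In a toxicity assay on CCRF-CEM cells (Homo sapiens) for cytotoxicity (a higher number here means that more compound is tolerated, a lower number that less compound is tolerated), compound 1 `Nc1cccc2c1nc(-c1c(F)cccc1F)n2Cc1c(F)cccc1F` gives 26.3 uM and compound 2 `Fc1cccc(F)c1Cn1c(-c2c(F)cccc2F)nc2c(Cl)cccc21` gives 30.4 uM. The change between them, chloro in place of amino on an aromatic carbon, gives a 1.2-fold higher number from compound 1 to compound 2 (0.06 log units; within the scatter).

In this assay, compound 3 `CC(=O)N(C)c1cccc2c1nc(-c1c(F)cccc1F)n2Cc1c(F)cccc1F` gives > 100 uM, which is a limit and not a number. It stands at the limit of > 100 uM in this assay, at which 1 of the 3 values shown sits. Putting acetyl(methyl)amino in place of amino gives an at least 3.8-fold higher number from compound 1 to compound 3 (0.58 log units; beyond the scatter), and putting it in place of chloro gives an at least 3.2-fold higher number from compound 2 to compound 3 (0.51 log units; beyond the scatter). Both steps are bounds, not exact sizes.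

Compound 4 `CN(C)C(=O)c1cccc2c1nc(-c1c(F)cccc1F)n2Cc1c(F)cccc1F` has dimethylcarbamoyl in place of acetyl(methyl)amino on an aromatic carbon. Within the data shown here, no measured step exchanges these two groups, so the two steps into compound 3 are the nearest guides. They show that a change at this place can move the number beyond the scatter, but they do not show what this exchange will do.

A modest move toward a lower number is expected, and only that direction can be read, since compound 3 already sits at the limit of > 100 uM. The expected step is an at least 1.4-fold lower number from compound 3 to compound 4 (0.15 log units; that floor lies within the scatter), and a reading at the limit would be no surprise. For compound 4 the estimate is 70 uM, with an expected range from 30 uM to 100 uM.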

Compound 4, half-maximal toxic concentration: 80.1 uM
Beside the measured number, compound 4's estimate is 1.1-fold (0.06 log units) below it, and the stated range covers the measured number.
By their numbers in this assay, from the lowest: compounds 1 and 2 (each within the scatter of the next); then compound 4. At a limit, above all of these: compound 3.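

In this assay, dimethylcarbamoyl has the same atoms as acetyl(methyl)amino, joined differently, and it too lifts the number beyond the scatter. In place of chloro it gives a 2.6-fold higher number from compound 2 to compound 4 (0.42 log units; beyond the scatter) and in place of amino it gives a 3.0-fold higher number from compound 1 to compound 4 (0.48 log units; beyond the scatter). Among these four compounds, then, the higher numbers at this place are not tied to one group: both five-atom amide groups, in compound 3 and compound 4, stand above amino in compound 1 and chloro in compound 2. The exchange between the two amide groups reads only as an at least 1.2-fold lower number from compound 3 to compound 4 (0.09 log units; that floor lies within the scatter), which does not fix its size, because compound 3 stands at a limit: the limit of > 100 uM in this assay, at which 1 of the 4 values shown sits.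

The compounds shown leave open how far the direction of the amide matters, since the true number of compound 3 remains unknown. They also leave open whether a group such as a nitrile, a carboxylic acid or a morpholine at this place would sit with compound 4 or with compound 1 and compound 2, and whether a longer chain on the amide nitrogen would shift the number further.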